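A few compounds are considered here, and "the series" means these few. Any claim that something is new, unique, unknown or untested is made for them only; others in the source may bear on it.

Measured compounds in a functional assay on PC-3 cells (Homo sapiens) for inhibition, read by MTT assay, with a stated time of 48 h; on this read-out higher numbers stand for weaker inhibition and lower numbers for stronger inhibition:
- compound 1 `C=C1CC[C@@H]2[C@](C)(CO)[C@H](O)CC[C@@]2(C)[C@@H]1CC(Sc1nccs1)C1=CCOC1=O`: 14000 nM
- compound 2 `C=C1CC[C@@H]2[C@](C)(CO)[C@H](O)CC[C@@]2(C)[C@@H]1C/C=C1/C(=O)OC[C@H]1OC(=O)CSc1ccc([N+](=O)[O-])cc1`: 17000 nM
- compound 3 `C=C1CC[C@@H]2[C@](C)(CO)[C@H](O)CC[C@@]2(C)[C@@H]1C/C=C1/C(=O)OC[C@H]1OC(=O)CCCSc1ccc(OC)cc1`: 19000 nM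

All three values of this assay sit close together. Compound 3 gives the highest number of the three, yet its gaps to compound 2 and to compound 1 are both within the scatter, so no order among the three can be read from these numbers. Going by the values given here, the one single-point comparison available, a 1.1-fold higher number from compound 2 to compound 3 (0.05 log units; within the scatter), also lies within the scatter; it concerns the chain between the ester carbonyl and the sulfur together with the aryl group on that sulfur.

Compound 4 `C=C1CC[C@@H]2[C@](C)(CO)[C@H](O)CC[C@@]2(C)[C@@H]1C/C=C1/C(=O)OC[C@H]1OC(=O)CCCSc1cccs1` differs from compound 3 by thiophen-2-yl in place of 4-methoxyphenyl on a sulfur. Among the compounds with values here, no measured pair changes only the aryl group on the sulfur, so nothing directly bears on this step; the only nearby comparison, a 1.1-fold higher number from compound 2 to compound 3 (0.05 log units; within the scatter), was flat. With the whole series spanning less than the scatter, the step for compound 4 is expected to be a 1.1-fold lower number from compound 3 to compound 4 (0.02 log units; within the scatter), that is, no change beyond the scatter in this assay.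

Compound 4 is therefore estimated at 18000 nM, with a range from 8000 nM to 42000 nM.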

Compound 4, half-maximal inhibitory concentration: 16000 nM
The estimate for compound 4 lay 1.1-fold (0.05 log units) above the measured number; measured number inside the range.
By their numbers in this assay, from the lowest: compounds 1, 4, 2 and 3 (each within the scatter of the next).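

In this assay, going by these compounds alone, thiophen-2-yl in place of 4-methoxyphenyl on a sulfur gives a 1.2-fold lower number from compound 3 to compound 4 (0.07 log units; within the scatter) and is the first step that changes the aryl group alone, so a five-membered aromatic ring with 1 hetero atom and a six-membered aromatic ring of carbon only cannot be told apart at this position. The wider change of 2-((thiophen-2-yl)sulfanyl)ethyl in place of (4-nitrophenyl)sulfanyl gives a 1.1-fold lower number from compound 2 to compound 4 (0.03 log units; within the scatter) and is equally flat. No measurement on these compounds offers an explanation for these flat steps.

As far as these compounds go, whether any group on this sulfur can move the number beyond the scatter stays open. An amine or a carboxylic acid in place of thiophen-2-yl, and a longer chain carrying the same (thiophen-2-yl)sulfanyl, would test this.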